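The source may report more compounds than this note shows. Statements on the series, on what has been measured and on what is new or still open speak of the compounds shown alone.

Measured so far:
- Compound 1 `Nc1scc(CN2CCN(c3cccc4ccccc34)CC2)c1C(=O)c1ccc(Cl)cc1` gives 2.9%
- Compound 2 `Nc1scc(CN2CCN(c3cccc(F)c3)CC2)c1C(=O)c1ccc(Cl)cc1` gives -86%

In a functional assay on CHO cells with adenosine receptor A1 (Homo sapiens) as the target, read by cAMP accumulation and immunoassay, with a stated time of 6 min, tested at 1 uM (a lower number here means a stronger effect, a higher number a weaker effect of the compound at the concentration tested), compound 2 holds the lowest of the two numbers; its nearest neighbour is compound 1, and the step of a number 88.9 percentage points lower from compound 1 to compound 2 (beyond the scatter) is large. Compound 3 `Nc1scc(CN2CCN(c3cc(F)ccc3F)CC2)c1C(=O)c1ccc(Cl)cc1` differs from compound 2 by fluoro in place of hydrogen on an aromatic carbon. Going by the values given here, the one measured step swapped a whole ring, not a single atom on it, so nothing measured bears directly on this change, and no step beyond the scatter is expected. Compound 3 is therefore estimated at -80%, within -100% to -50%, meaning an expected step of a number 6 percentage points higher from compound 2 to compound 3 (within the scatter).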

Compound 3, a percentage reported as activity, at one concentration (the size of the read-out at that concentration, not a potency): -59%
Beside the measured number, compound 3's estimate is 21 percentage points below it, and the stated range covers the measured number.
By their numbers in this assay, from the lowest: compound 2; then compound 3; then compound 1.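

In this assay, one added fluoro, ortho to a large group and para to a fluoro group, is enough to shift the read-out, with a number 27 percentage points higher from compound 2 to compound 3 (beyond the scatter), so even a single heavy atom at this position counts. The 2,5-difluorophenyl group still stays clearly on the low side of naphthalen-1-yl, with a number 61.9 percentage points lower from compound 1 to compound 3 (beyond the scatter). Nothing measured here explains why this added fluoro acts as it does.

The compounds shown leave open whether this shift belongs to fluoro itself or to any group at this position. A chloro, a methoxy or an amine at the same place would separate the two.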